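Swapping the quinoline attachment: what to expect for compound 3

A few compounds are considered here, and "the series" means these few. Any claim that something is new, unique, unknown or untested is made for them only; others in the source may bear on it.

The two measured compounds in a functional assay on the whole organism (blood) with Rattus norvegicus as the target, with stated times of 24 h and 1 h, at a dose of 5 mg/kg by the intraperitoneal route (a higher number here means a stronger effect of the compound at the dose given, a lower number a weaker effect), are:
compound 1 `COc1ccc(Cl)cc1C(=O)NCCC1CCN(S(=O)(=O)NC(=O)NC[C@@H]2C[C@@H]3C=C[C@@H]2C3)CC1`, which gives 37%
compound 2 `COc1ccc2nccc(C(=O)NCCC3CCN(S(=O)(=O)NC(=O)NC[C@@H]4C[C@@H]5C=C[C@@H]4C5)CC3)c2c1`, which gives 10%

For the measured compounds named here, compound 2 stands lowest of the two numbers in this assay; the only measured step, a number 27 percentage points lower from compound 1 to compound 2 (beyond the scatter), separates it from compound 1 and lies beyond the scatter. That step replaced one aromatic group on the carbonyl carbon with another and was modest in size.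

Compound 3 `O=C(NC[C@@H]1C[C@@H]2C=C[C@@H]1C2)NS(=O)(=O)N1CCC(CCNC(=O)c2cccc3cccnc23)CC1` differs from compound 2 in one place: quinolin-8-yl in place of 6-methoxyquinolin-4-yl on a carbonyl carbon. Going by the values given here, no measured step involves quinolin-8-yl, so the one step available says little about this particular exchange beyond showing that the group on that carbonyl carbon can shift the read-out in this assay by a modest amount. Compound 2 already sits near the bottom of the scale, leaving little room downward.

The expected step from compound 2 to compound 3 is a number 5 percentage points higher from compound 2 to compound 3 (within the scatter), that is, nothing clearly beyond the scatter. Compound 3 is therefore estimated at 15%, with a range from 0% to 40%.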

Compound 3, a percentage reported as activity, at one dose (the size of the read-out at that dose, not a potency): 34%
Estimate against measurement, compound 3: 19 percentage points below; measured number inside the range.
By their numbers in this assay, from the lowest: compound 2; then compounds 3 and 1 (each within the scatter of the next).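

In this assay, quinolin-8-yl in place of 6-methoxyquinolin-4-yl on the carbonyl carbon gives a number 24 percentage points higher from compound 2 to compound 3 (beyond the scatter), so carrying a quinoline on this carbonyl carbon does not by itself tie a compound to the low read-out of compound 2. Set against the non-quinoline group, quinolin-8-yl in place of 5-chloro-2-methoxyphenyl gives a number 3 percentage points lower from compound 1 to compound 3 (within the scatter), so these two quite different groups cannot be told apart in this read-out. Nothing available explains why these groups behave as they do.

The exchange from compound 2 to compound 3 moves the attachment point on the quinoline and removes the methoxy group at once, and the compounds shown cannot separate these two changes. Plain quinolin-4-yl on the same carbonyl carbon would pull them apart.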